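Methoxyphenyl for Methylphenyl on a Tolerated Chain

A few compounds are considered here, and "the series" means these few. Any claim that something is new, unique, unknown or untested is made for them only; others in the source may bear on it.

Measured so far in a toxicity assay on MT2 cells (Homo sapiens) for cytotoxicity, read by XTT assay, with a stated time of 4 days; a higher number here means that more compound is tolerated, a lower number that less compound is tolerated:
- Compound 1 `Cc1nc(C)c([C@H](OC(C)(C)C)C(=O)O)c(N2CCC(C)(C)CC2)c1-c1ccc(Cc2ccccc2)cc1`: >= 20000 nM, a limit of the assay.
- Compound 2 `Cc1nc(C)c([C@H](OC(C)(C)C)C(=O)O)c(N2CCC(C)(C)CC2)c1-c1ccc(Oc2ccccc2)cc1`: >= 20000 nM, a limit of the assay.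
- Compound 3 `Cc1ccc(CCOc2ccc(-c3c(C)nc(C)c([C@H](OC(C)(C)C)C(=O)O)c3N3CCC(C)(C)CC3)cc2)cc1`: >= 33500 nM, a limit of the assay.

All three values are limits rather than numbers, so a step that the two limits leave unreadable from compound 1 to compound 2, a step that the two limits leave unreadable from compound 1 to compound 3 and a step that the two limits leave unreadable from compound 2 to compound 3 cannot be sized. Compound 3 stands at the limit of >= 33500 nM in this assay, at which 1 of the 3 values shown sits, while the other two sit at the limit of >= 20000 nM in this assay, at which 2 of the 3 values shown sit. Compound 4 `COc1cccc(CCOc2ccc(-c3c(C)nc(C)c([C@H](OC(C)(C)C)C(=O)O)c3N3CCC(C)(C)CC3)cc2)c1` differs from compound 3 by 3-methoxyphenyl in place of 4-methylphenyl on a saturated chain carbon, two bonds along the chain from an oxygen on an aromatic ring. The steps into compound 3 altered this same chain, yet neither is readable, and no step beyond the scatter is foreseen in this assay. Compound 4 is estimated at 33500 nM, between 15000 nM and 60000 nM. The expected step is a number no higher from compound 3 to compound 4 (the limit leaves the size open), most likely again only a limit.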

Compound 4, half-maximal cytotoxic concentration: >= 33500 nM
Compound 4 was reported as a limit; the forecaster's own chance of this, stated with the estimate: 85%; the middle value sits exactly at the limit.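

Among these compounds, compound 4, like compound 1, compound 2 and compound 3, is reported only as a limit in this assay, so no step among them can be read. The compounds shown leave open at what concentration any of them harms the cells, and whether changing the chain matters.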